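A few compounds are considered here, and "the series" means these few. Any claim that something is new, unique, unknown or untested is made for them only; others in the source may bear on it.

Working notes on the series. The set comprises compound 1 `Cn1c(-c2ccc([N+](=O)[O-])cc2)nc2cc(C(F)(F)F)ccc21`, compound 2 `CC(=O)Nc1ccc(-c2nc3cc(C(F)(F)F)ccc3n2C)cc1`, compound 3 `O=[N+]([O-])c1ccc(-c2nc3cc(Cl)c(Cl)cc3[nH]2)cc1` and the not yet measured compound 4 `CC(=O)Nc1ccc(-c2nc3cc(Cl)c(Cl)cc3[nH]2)cc1`. Tolerability is read in an ADME assay on Vero cells (Chlorocebus sabaeus) for cytotoxicity; a lower number here means that less compound is tolerated, a higher number that more compound is tolerated.

In this assay compound 1 gives > 100000 nM, which is a limit of the assay and not a number. In this assay compound 2 gives > 100000 nM, again a limit. The change from compound 1 to compound 2 is acetamido in place of nitro on an aromatic carbon, and the step that the two limits leave unreadable from compound 1 to compound 2 is of unreadable size because the limit of > 100000 nM in this assay, at which 2 of the 3 values shown sit, holds both ends.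

Compound 3 sits on a different core; the difference between the two cores is not broken down here. In this assay compound 3 gives >= 100000 nM, a limit as well, which is the limit of >= 100000 nM in this assay, at which 1 of the 3 values shown sits.

Compound 4 carries the same change on the core of compound 3: acetamido in place of nitro on an aromatic carbon. The place is the same word for word as in the earlier pair, so the two changes are the same change. The expected step is a step that the limit leaves unreadable from compound 3 to compound 4, a figure that rests on the earlier pair, where a step that the two limits leave unreadable from compound 1 to compound 2 left both ends at the limit, and on compound 3 already standing at a limit. Compound 4 is therefore estimated at 150000 nM in this assay, with an expected range from 80000 nM to 400000 nM, and the assay is expected most likely to report only a limit once more. The measured value of compound 4 will tell whether that holds.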

Compound 4, half-maximal cytotoxic concentration: > 100000 nM
Compound 4: a limit, no number; the forecaster's own chance of this, stated with the estimate: 85%; the middle value is on the limit's open side.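

No new step can be read between compound 3 and compound 4: in this assay both stand at limits of the assay, not at numbers. The compounds shown leave open how much compound is tolerated past these limits, and whether acetamido in place of nitro on an aromatic carbon shifts tolerability at all on either core.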